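From a triazole diol to a short pyrrolidine chain

The source may hold more compounds than are shown below. What is called first, only, known or untested is meant among the compounds shown, and "the series" means these compounds.

Measured so far in a functional assay on HCT-116 cells (Homo sapiens) for cytotoxicity, read by MTT assay, with a stated time of 72 h; a lower number here means a stronger inhibitor, a higher number a weaker inhibitor:
Compound 1 `CN(C)CCCCCn1c2c(c3ccccc31)C(=O)c1c[n+]([O-])c3ccccc3c1C2=O` gives 470 nM
Compound 2 `O=C1c2c[n+]([O-])c3ccccc3c2C(=O)c2c1c1ccccc1n2Cc1cn(C[C@H](O)CO)nn1` gives 400 nM
Compound 3 `CC1(C)OCC(Cn2cc(Cn3c4c(c5ccccc53)C(=O)c3c[n+]([O-])c5ccccc5c3C4=O)nn2)O1` gives 70 nM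

Compound 2 and compound 1 sit together within the scatter, while compound 3 lies lower, beyond it. Compound 4 `O=C1c2c[n+]([O-])c3ccccc3c2C(=O)c2c1c1ccccc1n2CCN1CCCC1` is not yet measured. It differs from compound 2 on a saturated chain carbon bound to an aromatic nitrogen: (pyrrolidin-1-yl)methyl in place of 1-(2,3-dihydroxypropyl)-1H-1,2,3-triazol-4-yl on a saturated chain carbon bound to an aromatic nitrogen. The closest guide is a 1.2-fold lower number from compound 1 to compound 2 (0.07 log units; within the scatter), a swap between the same triazole group and a 4-(dimethylamino)butyl group. The larger 5.7-fold lower number from compound 2 to compound 3 (0.76 log units; beyond the scatter) introduces 2,2-dimethyl-1,3-dioxolan-4-yl, which compound 4 lacks, so it bears less on this change. No shift beyond the scatter is therefore expected, and the estimated change is a 1.1-fold lower number from compound 2 to compound 4 (0.06 log units; within the scatter). For compound 4 the expected value is 350 nM (range 120 nM to 1000 nM).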

Compound 4, half-maximal inhibitory concentration: 270 nM
For compound 4 the middle estimate is 1.3-fold (0.11 log units) above the measured one; the measured number falls inside the stated range.
By their numbers in this assay, from the lowest: compound 3; then compounds 4, 2 and 1 (each within the scatter of the next).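

In this assay, putting the far smaller (pyrrolidin-1-yl)methyl group in place of the triazole diol group gives a 1.5-fold lower number from compound 2 to compound 4 (0.17 log units; within the scatter) and so does not move the number beyond the scatter, even with the triazole ring and both hydrogen-bond donors gone. The 4-(dimethylamino)butyl chain compares the same way, with a 1.7-fold lower number from compound 1 to compound 4 (0.24 log units; within the scatter) as the step to the shorter chain ending in a pyrrolidine ring. No measured evidence explains why these changes leave the number so little moved. On these data alone, whether a piperidine or morpholine ring in place of the pyrrolidine, or a longer chain carrying the same ring, would shift the number beyond the scatter stays open.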